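Working notes: from compound 2 to compound 3

The compounds below may be only part of what the source reports. "The series", "measured", "known", "first", "only" and "open" are said of these compounds alone.

In a functional assay on MCF7 cells (Homo sapiens) for antiproliferative activity, read by MTT assay, with stated times of 24 h and 72 h (on this read-out higher numbers stand for weaker inhibition and lower numbers for stronger inhibition), compound 1 (`COc1ccc([C@@H]2[C@H](Oc3ccccc3)C(=O)N2c2cc(OC)c(OC)c(OC)c2)cc1`) gives 35000 nM and compound 2 (`COc1cc(N2C(=O)[C@@H](Oc3ccccc3)[C@H]2c2ccc(SC)cc2)cc(OC)c1OC`) gives 7700 nM. Going by the values given here, compound 2 therefore holds the lower of the only two numbers available.

Compound 3 (`CCOC(=O)/C=C/c1ccc([C@@H]2[C@H](Oc3ccccc3)C(=O)N2c2cc(OC)c(OC)c(OC)c2)cc1`) has 2-(ethoxycarbonyl)ethenyl in place of methylsulfanyl on an aromatic carbon, para to a large group: 2-(ethoxycarbonyl)ethenyl in place of methylsulfanyl on an aromatic carbon.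

Among the compounds with values here, one measured step bears on this change: a 4.5-fold lower number from compound 1 to compound 2 (0.66 log units; beyond the scatter), a modest step beyond the scatter, with methylsulfanyl in place of methoxy. Within the data shown here, it is a single step between two small groups, so it sets no trend, and no measured compound carries a group of this size at this place. The expectation in this assay is therefore a modest move toward a higher number, with the direction uncertain, since compound 2 sits at the low end with 7700 nM.

The expected change is a 2.3-fold higher number from compound 2 to compound 3 (0.37 log units; beyond the scatter). For compound 3 the estimated value is 18000 nM, with an expected range of 4000 nM to 70000 nM.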

Compound 3, half-maximal inhibitory concentration: 87000 nM
Estimate against measurement, compound 3: 4.8-fold (0.68 log units) below, and the stated range ends below it.
By their numbers in this assay, from the lowest: compound 2; then compound 1; then compound 3.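

In this assay, replacing methylsulfanyl with 2-(ethoxycarbonyl)ethenyl on this aromatic carbon, para to a large group, gives an 11-fold higher number from compound 2 to compound 3 (1.05 log units; beyond the scatter) as a large step toward weaker inhibition. Against methoxy at the same place, the same group gives a 2.5-fold higher number from compound 1 to compound 3 (0.40 log units; beyond the scatter) as a modest step in the same direction, so among these three groups it gives the weakest inhibition, and both steps are beyond the scatter. The earlier pair showed only that methylsulfanyl gives stronger inhibition than methoxy here; compound 3 shows that this place also responds strongly to a longer group, and that a larger group does not preserve the gain seen with compound 2.

No measurement on hand bears on the reason for this result.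

Going by these compounds alone, whether the change follows from the ethyl ester, the double bond or the length of the chain stays open, since the three compounds differ at this place by only three groups. A carboxylic acid, a primary amide or a saturated chain of the same length at this place would help separate these features.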